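A few compounds are considered here, and "the series" means these few. Any claim that something is new, unique, unknown or untested is made for them only; others in the source may bear on it.

Going by the values given here, compound 2 `CCOC(=O)CCCCCOc1cccc(CN(C(=O)c2ccc(-c3cccc(-c4nnc(C)o4)c3)cc2)C(C)C)c1` is one of two compounds measured in an ADME assay on HEK293 cells (Homo sapiens) for cytotoxicity, read by CellTiter-Glo and resazurin assay, with a stated time of 72 h; on this read-out higher numbers stand for an effect only at larger amounts of compound and lower numbers for an effect already at smaller amounts. In this assay compound 2 gives > 26000 nM, which is a limit of the assay rather than a number. Its neighbour compound 1 `CCOC(=O)CCCCCOc1cccc(CN(C(=O)c2ccc(-c3cnc(OC)nc3OC)cc2)C(C)C)c1` in this assay gives > 26000 nM, also a limit. The step that the two limits leave unreadable from compound 1 to compound 2 therefore cannot be read, and the limit of > 26000 nM in this assay, at which 2 of the 2 values shown sit, places both values at the same limit. Compound 3 `CCOC(=O)CCCCCOc1cccc(CN(C(=O)c2ccc(-c3cccc(C(F)(F)F)c3)cc2)C(C)C)c1` has not yet been measured in this assay; it differs from compound 2 by trifluoromethyl in place of 5-methyl-1,3,4-oxadiazol-2-yl on an aromatic carbon. Among the compounds with values here, no measured step bears on this change, and the single step that exists is unreadable, so no direction beyond the scatter can be anticipated. Compound 3 is therefore expected to remain at the limit, with an estimated 30000 nM (range 15000 nM to 80000 nM). This estimate means a step that the limit leaves unreadable from compound 2 to compound 3 that is expected to show no change beyond the scatter.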

Compound 3, half-maximal effective concentration: > 26000 nM
Compound 3 was reported as a limit (the forecaster's own chance of this, stated with the estimate: 85%); the middle value is on the limit's open side.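

The steps among compound 1, compound 2 and compound 3 cannot be read in this assay, as all three values are limits of the assay: the limit of > 26000 nM in this assay, at which 3 of the 3 values shown sit.

The compounds shown leave open whether these three differ at all in this assay, and at what amount of compound any of them would show an effect.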